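This account rests on a few compounds, and the source may have more. Where it says the series, first, only, none or still open, it means among the compounds named here.

The measured compounds are two. Compound 1 `CC(C)(N)CC(=O)N[C@@H]1CCc2ccccc2N(Cc2ccc(-c3ccccc3C(N)=O)cc2)C1=O` gives, in a functional assay (Pituitary gland cell) with Rattus norvegicus as the target (on this read-out lower numbers stand for an effect already at smaller amounts and higher numbers for an effect only at larger amounts of compound), 0.08 uM. Compound 2 `CC(C)(N)CC(=O)N[C@@H]1CCc2ccccc2N(Cc2ccc(-c3ccccc3C(=O)NCCO)cc2)C1=O` gives in this assay 3 uM.

Among the measured compounds shown here, compound 2 holds the highest of the two numbers in this assay; its only neighbour is compound 1, and the step between them, a 38-fold higher number from compound 1 to compound 2 (1.57 log units; beyond the scatter), lies beyond the scatter. Compound 3 `CCCCCNC(=O)c1ccccc1-c1ccc(CN2C(=O)[C@H](NC(=O)CC(C)(C)N)CCc3ccccc32)cc1` is yet to be measured in this assay. It differs from compound 2 by propyl in place of hydroxy on a saturated chain carbon, two bonds along the chain from an amide-type nitrogen. For the measured compounds named here, no measured step changes this part of the molecule in the same way; the only step at hand, a 38-fold higher number from compound 1 to compound 2 (1.57 log units; beyond the scatter), shows that putting 2-hydroxyethyl on that amide-type nitrogen moved the number strongly upward, and compound 3 keeps a chain on that nitrogen while losing the hydroxy. Whether pentyl behaves more like the hydrogen of compound 1 or like the 2-hydroxyethyl of compound 2 cannot be settled from these two points, so the expected step of a 1.5-fold lower number from compound 2 to compound 3 (0.18 log units; within the scatter) is set near none beyond the scatter, with wide bounds. Compound 3 is accordingly estimated at 2 uM in this assay, expected to lie between 0.4 uM and 10 uM.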

Compound 3, concentration for half-maximal effect: > 1 uM
Compound 3 gave a limit, no number; the forecaster's own chance of this, stated with the estimate: 5%; the middle value does not contradict the limit.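

In this assay compound 3 gave a limit and no number: the limit of > 1 uM in this assay, at which 1 of the 3 values shown sits.

The step between compound 2 and compound 3 cannot be read, so the swap of hydroxy for propyl on the saturated chain carbon has no size, and the order of these two compounds stays unsettled. What the result adds lies in the comparison with the unsubstituted amide: pentyl in place of hydrogen on the amide-type nitrogen gives an at least 12-fold higher number from compound 1 to compound 3 (1.09 log units; beyond the scatter), a large change in the same direction as the one seen with 2-hydroxyethyl, a 38-fold higher number from compound 1 to compound 2 (1.57 log units; beyond the scatter). Among the three compounds shown, a chain on this nitrogen therefore goes with a higher number whether or not it carries the hydroxy, and none of them goes against this.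

Going by these compounds, how far the true value of compound 3 lies beyond its limit remains open, and with it whether pentyl is better or worse tolerated than 2-hydroxyethyl. Also open, on these data alone, is how a single methyl on that nitrogen, or an amine or a carboxylic acid at the end of the chain, would read in this assay.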